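The source may report more compounds than this note shows. Statements on the series, on what has been measured and on what is new or still open speak of the compounds shown alone.

Of the compounds shown here, two with a shared core have been measured so far in an ADME assay on microsomes from liver (Homo sapiens) for metabolic stability, with a stated time of 10 min (on this read-out higher numbers stand for a more stable compound and lower numbers for a less stable compound), and their results are close. Compound 1 (`COc1cccc(F)c1COC(c1ccc([C@]2(S(=O)(=O)c3ccc(F)cc3)CCN(C(=O)[C@H]3CC[C@H](C(=O)O)CC3)C2)cc1)(C(F)(F)F)C(F)(F)F`) gives 82% and compound 2 (`O=C(O)[C@H]1CC[C@H](C(=O)N2CC[C@](c3ccc(C(OCC4CC4)(C(F)(F)F)C(F)(F)F)cc3)(S(=O)(=O)c3ccc(F)cc3)C2)CC1`) gives 75% in this measurement. These two numbers lie within the usual scatter of each other, so the data do not separate the compounds.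

Compound 3 (`O=C(O)[C@H]1CC[C@H](C(=O)N2CC[C@](c3ccc(C(OCC4CCC4)(C(F)(F)F)C(F)(F)F)cc3)(S(=O)(=O)c3ccc(F)cc3)C2)CC1`) has not yet been measured. It carries cyclobutyl in place of cyclopropyl on a saturated chain carbon bound to an oxygen on a saturated carbon, and the full difference from compound 2 is cyclobutyl in place of cyclopropyl on a saturated chain carbon bound to an oxygen on a saturated carbon in terms of what leaves and enters.

For the measured compounds named here, only one measured step touches this same place, with cyclopropyl in place of 2-fluoro-6-methoxyphenyl, and it is a number 7 percentage points lower from compound 1 to compound 2 (within the scatter) as the whole effect of that exchange. A single step is thin evidence, but it gives no sign of a large effect at this place. The expected result is a number 3 percentage points lower from compound 2 to compound 3 (within the scatter) with no shift beyond the scatter. Compound 3 is estimated at 72% with a likely range from 58% to 85% in this measurement.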

Compound 3, percent of the compound remaining: 85%
Compound 3: the middle estimate sits 13 percentage points below what was measured; the range from low to high includes it.
By their numbers in this assay, from the lowest: compounds 2, 1 and 3 (each within the scatter of the next).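

In this assay, exchanging the group on this saturated chain carbon bound to an oxygen gives a number 10 percentage points higher from compound 2 to compound 3 (within the scatter) for cyclobutyl in place of cyclopropyl, and a number 3 percentage points higher from compound 1 to compound 3 (within the scatter) for cyclobutyl in place of 2-fluoro-6-methoxyphenyl. For the compounds shown here, the earlier pair compared only two groups, whereas three now stand at this place, and no exchange among them gives a step beyond the scatter, so this read-out does not separate a three-membered ring, a four-membered ring and a substituted phenyl ring in these three compounds. No separate evidence bears on this result, so the data offer no explanation for these numbers.

All three groups at this place are rings, which leaves open whether an open chain such as n-butyl, or a group carrying an amine, would also stay within the scatter of these compounds. As far as these compounds go, whether the small differences among cyclopropyl, cyclobutyl and 2-fluoro-6-methoxyphenyl reflect any real effect also stays open, as each lies within the usual spread of repeated measurements.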